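The source may hold more compounds than are shown below. What is called first, only, known or untested is meant among the compounds shown, and "the series" means these compounds.

Working notes on the amide series. Among the compounds with values here, compound 2 `C=CC1=C(C(=O)Nc2ccc(OCC)cc2)C(c2ccc(OC)cc2)OC1` is the one compound in the set with a single number: in a functional assay on A549 cells (Homo sapiens) for cytotoxicity, read by MTT assay, with a stated time of 24 h (a higher number here means a weaker inhibitor, a lower number a stronger inhibitor), compound 2 gives 17600 nM. Compound 1 `C=CC1=C(C(=O)NCc2ccc(Cl)cc2)C(c2ccc(F)cc2)OC1` reaches only a limit in this assay, reported for compound 1 as > 100000 nM. Compound 3 `C=CC1=C(C(=O)Nc2ccc(OCC)cc2)C(c2ccc(F)cc2)OC1` is entered in this assay as "not active" (no number reported), without a number. Within the data shown here, no pair of measured compounds differing in one place is available, so nothing in the set fixes the size of any single change.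

Compound 4 `C=CC1=C(C(=O)NCc2ccc(C)cc2)C(c2ccc(OC)cc2)OC1` keeps the 4-methoxyphenyl part of compound 2 and differs from it on the amide-type nitrogen: 4-methylbenzyl in place of 4-ethoxyphenyl on an amide-type nitrogen. Compound 1, which also carries a benzyl-type group on that nitrogen, sits at the limit of > 100000 nM in this assay, at which 1 of the 3 values shown sits, which weighs against this change, though compound 1 and compound 2 are not a single-change pair. The step from compound 2 to compound 4 is therefore expected to weaken inhibition by a moderate amount, a 2.0-fold higher number from compound 2 to compound 4 (0.30 log units; within the scatter), beyond the usual scatter. In this assay compound 4 is estimated at 35000 nM, within 10000 nM to 100000 nM.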

Compound 4, half-maximal inhibitory concentration: > 100000 nM
Compound 4 ended at the assay's limit; the forecaster's own chance of this, stated with the estimate: 35%; middle value at least 2.8-fold (0.45 log units) from the limit.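

In this assay the series now has its first single-change pair: 4-methylbenzyl in place of 4-ethoxyphenyl on an amide-type nitrogen gives an at least 5.6-fold higher number from compound 2 to compound 4 (0.75 log units; beyond the scatter). Compound 4 sits at a limit of the assay, so this step gives a lower bound on the change and not its full size. With the 4-methoxyphenyl part held constant, the position on this nitrogen is shown to matter, and the weak result for a benzyl-type group no longer rests on compound 1 alone: the limit of > 100000 nM in this assay, at which 2 of the 4 values shown sit.

This change alters both the ring's attachment and its substituent, so the pair cannot separate the two; 4-ethoxybenzyl or 4-methylphenyl on this nitrogen would do so. From the compounds shown here alone, whether a chain ending in an amine or a carboxylic acid at this position would give a lower number than compound 2 remains open.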